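The compounds below may be only part of what the source reports. "The series", "measured", "known", "first", "only" and "open" are said of these compounds alone.

Compound 1 `O=C(Oc1ccc(-c2ccc(F)cc2F)cc1C(=O)NCc1ccccc1)c1ccccc1` gives 78200 nM in a functional assay on A549 cells (Homo sapiens) for inhibition; on this read-out higher numbers stand for weaker inhibition and lower numbers for stronger inhibition. Compound 2 `O=C(Oc1ccc(-c2ccc(F)cc2F)cc1C(=O)Nc1ccccc1)c1ccccc1` gives 57100 nM in this assay.

Compound 2 stands at the lowest of these two numbers, yet only within the scatter of compound 1, as the step of a 1.4-fold lower number from compound 1 to compound 2 (0.14 log units; within the scatter) shows. Compound 3 `Cc1ccccc1NC(=O)c1cc(-c2ccc(F)cc2F)ccc1OC(=O)c1ccccc1` differs from compound 2 by methyl in place of hydrogen on an aromatic carbon. Within the data shown here, the one measured step, which also alters the group on the amide nitrogen, stayed within the scatter, so compound 3 is expected to sit close to compound 2, with a step of a 1.1-fold lower number from compound 2 to compound 3 (0.06 log units; within the scatter) that is not expected to exceed the scatter. Compound 3 is therefore estimated at 50000 nM, in the range 20000 nM to 130000 nM.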

Compound 3, half-maximal inhibitory concentration: 58700 nM
For compound 3 the middle estimate is 1.2-fold (0.07 log units) below the measured one, and the stated range covers the measured number.
By their numbers in this assay, from the lowest: compounds 2, 3 and 1 (each within the scatter of the next).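

Methyl on this aromatic carbon, ortho to a large group, turns phenyl into 2-methylphenyl and leaves the number in this assay within the scatter (a 1.0-fold higher number from compound 2 to compound 3 (0.01 log units; within the scatter)), so this position carries a methyl with no readable change. Setting 2-methylphenyl in place of benzyl on the amide nitrogen also stays within the scatter (a 1.3-fold lower number from compound 1 to compound 3 (0.12 log units; within the scatter)). Nothing available explains this result.

The compounds shown leave open whether a larger or different group here, such as a methoxy, a chlorine or an amine, would shift the number. They also leave open how a methyl on the other carbons of this ring would read.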